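Ethyl-capped polyamines: lengthening the chain in compound 3

A few compounds are considered here, and "the series" means these few. Any claim that something is new, unique, unknown or untested is made for them only; others in the source may bear on it.

Measured in a functional assay on L1210 cells (Mus musculus) for inhibition, with a stated time of 48 h; a lower number here means a stronger inhibitor, a higher number a weaker inhibitor:
Compound 1 `CCNCCCCNCCCN`: > 100000 nM
Compound 2 `CCNCCCCNCCCNCC`: 100000 nM
Compound 3 `CCNCCCCNCCCCNCC`: not yet measured

Compound 1 reads > 100000 nM, which is a limit of the assay and not a number. For the measured compounds named here, compound 2, at 100000 nM, holds the only actual number in this assay. Going by the values given here, the one measured step, a number no higher from compound 1 to compound 2 (the limit leaves the size open), places ethyl in place of hydrogen on an amine nitrogen. On these data alone, its size stays open, as the limit of > 100000 nM in this assay, at which 1 of the 2 values shown sits, shows. The move to compound 3 is of another kind: (ethylamino)methyl in place of ethylamino on a saturated chain carbon, three bonds along the chain from an amine nitrogen, with (ethylamino)methyl in place of ethylamino on a saturated chain carbon, three bonds along the chain from an amine nitrogen. Among the compounds with values here, no measured step covers this change, so no step clearly beyond the scatter is expected in this assay, and the expected step is a 1.4-fold lower number from compound 2 to compound 3 (0.15 log units; within the scatter). Compound 3 is estimated at 70000 nM, with an expected range of 15000 nM to 200000 nM.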

Compound 3, half-maximal inhibitory concentration: 22000 nM
Estimate against measurement, compound 3: 3.2-fold (0.50 log units) above; low and high end bracket the measured number.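

In this assay, for the compounds shown here, (ethylamino)methyl in place of ethylamino on a saturated chain carbon, three bonds along the chain from an amine nitrogen, gives a 4.5-fold lower number from compound 2 to compound 3 (0.66 log units; beyond the scatter), the first step with a readable size. Going by these compounds alone, the earlier ethyl step cannot be read, so this is the first sign that the length of the chain at this position matters here. Putting (ethylamino)methyl in place of amino at the same place gives an at least 4.5-fold lower number from compound 1 to compound 3 (0.65 log units; beyond the scatter), and its full size stays open, since compound 1 carries a limit of the assay and not a number: the limit of > 100000 nM in this assay, at which 1 of the 3 values shown sits.

On these data alone, this rests on a single lengthening, so whether a longer chain, such as one ending in 2-(ethylamino)ethyl, would lower the number further remains open. Also open, as far as these compounds go, is how a propyl group in place of the ethyl caps would behave on the chain of compound 3.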